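Cyano for methyl on the benzamide arm of the series

The source may hold more compounds than are shown below. What is called first, only, known or untested is meant among the compounds shown, and "the series" means these compounds.

Measured so far:
compound 1 `COc1cc2oc(-c3cccc(NC(=O)c4ccc(Cl)cc4)c3)cc(=O)c2c(OC)c1OC` — 51.1%
compound 2 `COc1cc2oc(-c3ccc(NC(=O)c4ccc(C)cc4)cc3)cc(=O)c2c(OC)c1OC` — "active" (no number reported)

In a functional assay on UO-31 cells (Homo sapiens) for inhibition, read by sulforhodamine B assay, tested at 10 uM (a lower number here means less inhibition, a higher number more inhibition at the concentration tested (going by the name of the read-out)), compound 1 gives 51.1%. Within the data shown here, compound 2 is reported in this assay only as "active" (no number reported), with no number attached, so no single figure places it against compound 1; the two values show only that both compounds inhibit growth under these conditions. Among the measured compounds shown here, compounds 1 and 2 differ in more than one place, and no step between them is given, so nothing is said here of their order.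

Compound 3 `COc1cc2oc(-c3ccc(NC(=O)c4ccc(C#N)cc4)cc3)cc(=O)c2c(OC)c1OC` follows from compound 2 by one change: cyano in place of methyl on an aromatic carbon. Methyl leaves and cyano enters, turning the 4-methylphenyl into a 4-cyanophenyl on the carbonyl side of the amide. For the measured compounds named here, compound 3 has not been measured in this assay, and no step can be computed for it. The expectation is that compound 3 stays in the same region as compound 1 and compound 2, with no move beyond the scatter in either direction that the data would support. Compound 3 is estimated at 50%, within a range of 25% to 75%.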

Compound 3, a percentage reported as inhibition, at one concentration (the size of the read-out at that concentration, not a potency): "active" (no number reported)
The entry for compound 3 holds no number, so the estimate cannot be set against anything.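

In this assay compound 2 reads "active" (no number reported) and compound 3 reads "active" (no number reported) so no step can be read for the change from 4-methylphenyl to 4-cyanophenyl. No measurement offers an explanation for either result. Still open, as far as these compounds go, is whether cyano and methyl differ in this assay by more than the usual scatter.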